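Compound 3 to compound 4: one chloro group changes place

The source may report more compounds than this note shows. Statements on the series, on what has been measured and on what is new or still open speak of the compounds shown alone.

Measured so far in a functional assay on HT-29 cells (Homo sapiens) for cytotoxicity, read by sulforhodamine B assay; on this read-out lower numbers stand for stronger inhibition of growth and higher numbers for weaker inhibition of growth:
Compound 1 `COc1ccc(/C=N\NC(=S)NC(C)(C)CCC[C@](C)(O)[C@@H]2CC=C(C)CC2)cc1` gives 35200 nM
Compound 2 `CC1=CC[C@@H]([C@@](C)(O)CCCC(C)(C)NC(=S)N/N=C\c2ccccc2[N+](=O)[O-])CC1` gives 16800 nM
Compound 3 `CC1=CC[C@@H]([C@@](C)(O)CCCC(C)(C)NC(=S)N/N=C\c2ccccc2Cl)CC1` gives > 100000 nM as a limit

Compound 3 is the only one of the three at the limit of > 100000 nM in this assay, at which 1 of the 3 values shown sits, and so has no exact number. Compound 4 `CC1=CC[C@@H]([C@@](C)(O)CCCC(C)(C)NC(=S)N/N=C\c2ccc(Cl)cc2)CC1` has not yet been measured and differs from it in one group: 4-chlorophenyl in place of 2-chlorophenyl on a carbon with a double bond to nitrogen. In words, 4-chlorophenyl stands in place of 2-chlorophenyl on a carbon with a double bond to nitrogen.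

Within the data shown here, no measured step makes this exact change. The closest are an at least 2.8-fold higher number from compound 1 to compound 3 (0.45 log units; beyond the scatter) and an at least 5.9-fold higher number from compound 2 to compound 3 (0.77 log units; beyond the scatter), both of which replace another aryl group with 2-chlorophenyl. Compound 1, with its 4-methoxyphenyl group, gives 35200 nM and is the nearest guide for a group in that place. The expected result in this assay is a modest move toward stronger growth inhibition, written as an at least 2.2-fold lower number from compound 3 to compound 4 (0.34 log units; beyond the scatter), although a second limit remains possible. Compound 4 is estimated at 45000 nM, with an expected range from 15000 nM to 95000 nM.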

Compound 4, concentration for total growth inhibition: 22600 nM
Beside the measured number, compound 4's estimate is 2.0-fold (0.30 log units) above it; the range from low to high includes it.
By their numbers in this assay, from the lowest: compounds 2, 4 and 1 (each within the scatter of the next, the first and the last beyond it). At a limit, above all of these: compound 3.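

In this assay, 4-chlorophenyl in place of 2-chlorophenyl moves only the chloro group while keeping the same atoms, and that move alone turns a limit into a measured value, with an at least 4.4-fold lower number from compound 3 to compound 4 (0.64 log units; beyond the scatter). Going by these compounds, the starting point of this step is a limit, so its full size stays unknown: the limit of > 100000 nM in this assay, at which 1 of the 4 values shown sits. Compound 4 also lies within the scatter of the two other measured compounds, with a 1.3-fold higher number from compound 2 to compound 4 (0.13 log units; within the scatter) and a 1.6-fold lower number from compound 1 to compound 4 (0.19 log units; within the scatter), so among the four compounds shown only the one with 2-chlorophenyl stands apart.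

The compounds shown leave open how a phenyl group carrying an amine or a carboxylic acid would read in this assay. They also leave open whether a change away from the aryl group, such as a longer chain, would shift these values.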